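The compounds below may be only part of what the source reports. "The series", "measured", "known", "first", "only" and "open" are said of these compounds alone.

Three compounds share one core and differ only in the acyl group on the amide nitrogen. Compound 1 `CCCCCCCCCCCCCCNC(=O)[C@@H](NC(=O)c1cccs1)[C@@H](C)O` gives 36100 nM in a functional assay on MCF7 cells (Homo sapiens) for cytotoxicity, read by MTT assay, with a stated time of 48 h; a higher number here means a weaker inhibitor, a lower number a stronger inhibitor. Compound 2 `CCCCCCCCCCCCCCNC(=O)[C@@H](NC(=O)c1nccc2ccccc12)[C@@H](C)O` gives 22800 nM in this assay, and compound 3 `C/C=C/C=C/C(=O)N[C@H](C(=O)NCCCCCCCCCCCCCC)[C@@H](C)O` gives 27800 nM in this assay. Compound 2 sits among the three numbers without being set apart from either neighbour: the step of a 1.6-fold lower number from compound 1 to compound 2 (0.20 log units; within the scatter), and the step of a 1.2-fold higher number from compound 2 to compound 3 (0.09 log units; within the scatter). The remaining pair shows the same picture, with a 1.3-fold lower number from compound 1 to compound 3 (0.11 log units; within the scatter). The three acyl groups are thus not distinguished by the data.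

Compound 4 `CCCCCCCCCCCCCCCCCCNC(=O)[C@@H](NC(=O)c1nccc2ccccc12)[C@@H](C)O` differs from compound 2 in one place: butyl in place of hydrogen on a saturated chain carbon, ten or more bonds along the chain from an amide-type nitrogen. None of the three measured steps concerns the chain; all three vary the acyl group, and all lie within the scatter. Among the measured compounds shown here, the data hold no step of this kind to lean on. For the measured compounds named here, with no measured step bearing on the change, and with every measured step in this assay within the scatter, a step no larger than the scatter is expected, a 1.0-fold lower number from compound 2 to compound 4 (0.02 log units; within the scatter). Compound 4 is therefore estimated at 22000 nM in this assay, with a range from 8000 nM to 60000 nM.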

Compound 4, half-maximal inhibitory concentration: 30800 nM
Compound 4: the middle estimate sits 1.4-fold (0.15 log units) below what was measured; measured number inside the range.
By their numbers in this assay, from the lowest: compounds 2, 3, 4 and 1 (each within the scatter of the next).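

Compound 4 is the only compound shown that alters the chain rather than the acyl group, and in this assay butyl in place of hydrogen on a saturated chain carbon, ten or more bonds along the chain from an amide-type nitrogen, gives a 1.4-fold higher number from compound 2 to compound 4 (0.13 log units; within the scatter). The earlier compounds shown here said nothing about this position, and this one step now shows that, with the isoquinolin-1-yl acyl group in place, adding butyl there does not set compound 4 apart from compound 2 in this read-out, just as none of the acyl changes set their compounds apart. No accompanying measurement bears on this result or offers an explanation for it.

As far as these compounds go, the chain change is seen only once, so it remains open whether the same addition would stay within the scatter with the thiophen-2-yl or penta-1,3-dien-1-yl acyl groups. From the compounds shown here alone, it is also open whether a much shorter chain, or an amine or a carboxylic acid at the far end of the chain, would give a step that stands beyond the scatter in this assay.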